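This account rests on a few compounds, and the source may have more. Where it says the series, first, only, none or still open, it means among the compounds named here.

Compound 1 `O=C(/C=C\c1ccccc1)N1N=C(c2ccncc2)OC1c1c[nH]c2ccccc12` gives > 30 ug/mL in an ADME assay on PANC-1 cells (Homo sapiens) for cytotoxicity, read by MTT assay, with a stated time of 48 h (on this read-out higher numbers stand for weaker inhibition of growth and lower numbers for stronger inhibition of growth), a limit of the assay.
Compound 2 `O=C(/C=C\c1cccc([N+](=O)[O-])c1)N1N=C(c2ccncc2)OC1c1c[nH]c2ccccc12` gives > 30 ug/mL in this assay, likewise a limit.

Compound 2 therefore stands only at a limit in this assay, with no number attached to it. Compound 3 `Cc1ccc(/C=C\C(=O)N2N=C(c3ccncc3)OC2c2c[nH]c3ccccc23)cc1` differs from compound 2 by 4-methylphenyl in place of 3-nitrophenyl on a double-bonded chain carbon bound to a double-bonded chain carbon. Among the compounds with values here, the single measured step, a step that the two limits leave unreadable from compound 1 to compound 2, is the only one that bears on this change, and its size cannot be read because of the limit of > 30 ug/mL in this assay, at which 2 of the 2 values shown sit. No direction follows from it. For compound 3 the expected step is a step that the limit leaves unreadable from compound 2 to compound 3, nothing beyond the scatter, most likely ending again at the limit. The estimate for compound 3 is 40 ug/mL, from 15 ug/mL to 120 ug/mL.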

Compound 3, concentration for 50% growth inhibition: > 30 ug/mL
Compound 3 was reported as a limit; the forecaster's own chance of this, stated with the estimate: 75%; the middle value does not contradict the limit.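

Compound 3 sits at a limit in this assay, as do compound 1 and compound 2, so no new step can be read among them: the limit of > 30 ug/mL in this assay, at which 3 of the 3 values shown sit.
The compounds shown leave open whether any group in this place would give a readable number.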